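A few compounds are considered here, and "the series" means these few. Any claim that something is new, unique, unknown or untested is made for them only; others in the source may bear on it.

Measured in a functional assay on the whole organism for inhibition, with Mus musculus as the target, at a dose of 1 mg/kg by the oral route; on this read-out lower numbers stand for less inhibition and higher numbers for more inhibition at the one dose given (going by the name of the read-out):
Compound 1 `COc1cccc2c1c(O)c(C(=O)N(C)c1cc(F)ccc1F)c(=O)n2C` gives 90%.
Compound 2 `COc1cccc2c1c(O)c(C(=O)N(C)c1cccc(Cl)c1)c(=O)n2C` gives 85%.
Compound 3 `COc1cccc2c1c(O)c(C(=O)N(C)c1ccc(C(C)(C)C)cc1)c(=O)n2C` gives 84%.

Compound 3 stands lowest of the three numbers, yet its gaps to compound 2 and to compound 1 both lie within the scatter, so no order among the three is claimed. Compound 4 `COc1ccc(N(C)C(=O)c2c(O)c3c(OC)cccc3n(C)c2=O)cc1` differs from compound 3 by methoxy in place of tert-butyl on an aromatic carbon. Going by the values given here, the only step between measured compounds, a number 5 percentage points lower from compound 1 to compound 2 (within the scatter), also changes the ring on the amide-type nitrogen and stayed within the scatter; no measured step exchanges tert-butyl for methoxy. On that basis the writer expects no step beyond the scatter in this assay, with a number 2 percentage points lower from compound 3 to compound 4 (within the scatter) as the estimated step. Compound 4 is therefore estimated at 82%, within a range from 65% to 95%.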

Compound 4, a percentage reported as inhibition, in the whole organism at one dose (the size of the read-out at that dose, not a potency): 84%
Compound 4: the middle estimate sits 2 percentage points below what was measured; low and high end bracket the measured number.
By their numbers in this assay, from the lowest: compounds 3, 4, 2 and 1 (each within the scatter of the next).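

Going by these compounds alone, at the carbon para to a large group, methoxy takes the place of tert-butyl with no change at the digits printed from compound 3 to compound 4 (within the scatter) in this assay, the first measured exchange at this position, and it leaves the read-out within the scatter. Changing the whole ring on the amide-type nitrogen gives a number 1 percentage points lower from compound 2 to compound 4 (within the scatter) and a number 6 percentage points lower from compound 1 to compound 4 (within the scatter), so 4-methoxyphenyl stays within the scatter of both other rings at this dose. No measurement shown offers a reason for this. The compounds shown leave open whether an amine or a carboxylic acid at this carbon would also stay within the scatter.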